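Methyl for Hydrogen on the Five-Membered Ring

The compounds below may be only part of what the source reports. "The series", "measured", "known", "first", "only" and "open" are said of these compounds alone.

Of the compounds shown here, three of one series have been measured in an ADME assay on microsomes from liver (Homo sapiens) for metabolic stability, read by LC-MS, using NADPH, tested at 5 uM; a lower number here means that the compound disappears faster, a higher number that the compound lasts longer. Compound 1 `Cc1cc(-c2ccccc2)n(/C(N)=N/S(=O)(=O)c2cc(C)c(Cl)cc2SCc2cccc3ccccc23)n1` gives 0.256 h, compound 2 `Cc1cc(-c2ccccc2)n(/C(N)=N/S(=O)(=O)c2cc(C)c(Cl)cc2SCc2ccccc2C)n1` gives 0.154 h, and compound 3 `Cc1cc(S(=O)(=O)/N=C(\N)n2nccc2-c2ccccc2)c(SCc2ccccc2Cl)cc1Cl` gives 0.226 h. Compound 3 stands second highest of the three; its nearest neighbour is compound 1 and its furthest is compound 2, yet both gaps lie within the scatter. Within the data shown here, the only measured step, a 1.7-fold lower number from compound 1 to compound 2 (0.22 log units; within the scatter), concerns a different part of the molecule. Compound 4 `Cc1cc(-c2ccccc2)n(/C(N)=N/S(=O)(=O)c2cc(C)c(Cl)cc2SCc2ccccc2Cl)n1` differs from compound 3 by methyl in place of hydrogen on an aromatic carbon. Among the measured compounds shown here, no measured step bears directly on this change, so compound 4 is expected to show a 1.0-fold higher number from compound 3 to compound 4 (0.01 log units; within the scatter), nothing beyond the scatter, and its estimated half-life in this assay is 0.23 h, between 0.12 h and 0.45 h.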

Compound 4, half-life: 0.163 h
For compound 4 the middle estimate is 1.4-fold (0.15 log units) above the measured one; measured number inside the range.
By their numbers in this assay, from the lowest: compounds 2, 4, 3 and 1 (each within the scatter of the next).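

In this assay, methyl in place of hydrogen on the aromatic carbon of the five-membered ring now has a measured step (a 1.4-fold lower number from compound 3 to compound 4 (0.14 log units; within the scatter)), and that step stays inside the scatter. The changes at the other end of the molecule also stay inside it (a 1.1-fold higher number from compound 2 to compound 4 (0.02 log units; within the scatter); a 1.6-fold lower number from compound 1 to compound 4 (0.20 log units; within the scatter)), so the four compounds cannot be told apart here. Nothing at hand explains these numbers. On these data alone, whether an amine, a carboxylic acid or an ethyl group on this carbon would give a step beyond the scatter remains open.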